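The source may report more compounds than this note shows. Statements on the series, on what has been measured and on what is new or still open speak of the compounds shown alone.

Compound 1 `COc1cc2c(cc1OC)C(CC(=O)Nc1ccc(Cl)cc1)CC2`: 63%
Compound 2 `COc1cc2c(cc1OC)C(CC(=O)Nc1cccc(C)c1)CC2`: 29%

In a functional assay on the whole organism (strain Wistar) for inhibition, with Rattus norvegicus as the target, read by paw edema, with a stated time of 2 h, at a dose of 100 mg/kg (on this read-out lower numbers stand for less inhibition and higher numbers for more inhibition at the one dose given (going by the name of the read-out)), compound 1 gives 63%, the higher of the two numbers. Compound 2 gives 29%, and the step of a number 34 percentage points lower from compound 1 to compound 2 (beyond the scatter) shows how strongly the group on the amide-type nitrogen can matter. Compound 3 `COc1cc2c(cc1OC)C(CC(=O)Nc1ccc([N+](=O)[O-])cc1)CC2` has not been measured. Its change from compound 1 is nitro in place of chloro on an aromatic carbon. For the measured compounds named here, no measured step exchanges chloro for nitro, so the one measured step only shows that this part of the molecule is sensitive. A modest fall is expected for compound 3, a number 11 percentage points lower from compound 1 to compound 3 (beyond the scatter), with wide uncertainty. Compound 3 is expected to give 52%, between 30% and 72%.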

Compound 3, a percentage reported as inhibition, in the whole organism at one dose (the size of the read-out at that dose, not a potency): 36%
The estimate for compound 3 lay 16 percentage points above the measured number; measured number inside the range.
By their numbers in this assay, from the lowest: compounds 2 and 3 (each within the scatter of the next); then compound 1.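

Compound 1 and compound 3 carry their groups on the same aromatic carbon, para to a large group, so this step changes only the group: with nitro in place of chloro, the read-out moves by a number 27 percentage points lower from compound 1 to compound 3 (beyond the scatter). The earlier step changed both the group and where it sat, whereas this one shows that the choice of group alone matters on this carbon. No available evidence explains the size of this step. Still open, on these data alone, is how an amine or a carboxylic acid on this carbon would score in this assay. Also open, as far as these compounds go, is what a methyl group would give here, which would separate the effect of the group from that of its place.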